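A few compounds are considered here, and "the series" means these few. Any claim that something is new, unique, unknown or untested is made for them only; others in the source may bear on it.

Measured in a toxicity assay on MRC5 cells (Homo sapiens) for inhibition, read by MTT assay, with a stated time of 72 h; on this read-out higher numbers stand for weaker inhibition and lower numbers for stronger inhibition:
- compound 1 `O=S(=O)(O)Oc1ccc(CCO)cc1`: 106000 nM
- compound 2 `CCCC(=O)OCCc1ccc(O)c(O)c1`: 71500 nM

Compound 2 stands within the scatter of compound 1, so the two values do not separate. Compound 3 `CCCCCCCCCC(=O)OCCc1ccc(O)c(O)c1` differs from compound 2 by hexyl in place of hydrogen on a saturated chain carbon, three bonds along the chain from a carbonyl carbon. Within the data shown here, no measured pair shows this change, so the expectation is tentative. A moderate move toward stronger inhibition is expected in this assay, an estimated 2.9-fold lower number from compound 2 to compound 3 (0.46 log units; beyond the scatter). For compound 3 the estimated value is 25000 nM, with an expected range of 8000 nM to 70000 nM.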

Compound 3, half-maximal inhibitory concentration: 71100 nM
Beside the measured number, compound 3's estimate is 2.8-fold (0.45 log units) below it, outside the stated range (above it).
By their numbers in this assay, from the lowest: compounds 3, 2 and 1 (each within the scatter of the next).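

In this assay, hexyl in place of hydrogen on a saturated chain carbon, three bonds along the chain from a carbonyl carbon, gives a 1.0-fold lower number from compound 2 to compound 3 (0.00 log units; within the scatter) and so does not separate the two esters. Among these compounds, this is the first step read at this position, and it shows that the position accepts the hexyl group with the values of compound 2 and compound 3 staying within the scatter of each other. No available evidence bears on this result.

As far as these compounds go, whether a longer chain, or an amine or carboxylic acid at this position, would separate from compound 2 stays open. Among the compounds shown here, compound 1 differs from both esters in more than one place, so no step to it can be read.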